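One Aryl Swap on a Sulfonyl Sulfur

This account rests on a few compounds, and the source may have more. Where it says the series, first, only, none or still open, it means among the compounds named here.

Measured so far:
Compound 1, `COCC1CCN(c2c(S(=O)(=O)c3cc(F)cc(F)c3)cnc3cc(F)ccc23)CC1`, gives 83% in an assay on isolated protein for displacement of a labelled ligand from metabotropic glutamate receptor 5 (Homo sapiens), with a stated time of 60 min, tested at 1 uM; a higher number here means more inhibition at the concentration tested (going by the name of the read-out), a lower number less inhibition.
Compound 2, `CC1CCN(c2c(S(=O)(=O)c3cc(F)cc(F)c3)cnc3cc(F)ccc23)CC1`, gives 77% in this assay.

Compound 1 and compound 2 sit within the scatter of each other: the step of a number 6 percentage points lower from compound 1 to compound 2 (within the scatter), which comes from hydrogen in place of methoxy on a saturated chain carbon bound to a saturated ring carbon, is too small to separate them, so the number of compound 1 cannot be called higher than that of compound 2.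

Compound 3, `COCC1CCN(c2c(S(=O)(=O)c3cccc(C#N)c3)cnc3cc(F)ccc23)CC1`, is not yet measured. It keeps the methoxy chain of compound 1 and differs from it by 3-cyanophenyl in place of 3,5-difluorophenyl on a sulfonyl sulfur. Among the measured compounds shown here, the only measured step concerns the methoxy chain, not the group on the sulfonyl sulfur, so no measured step bears on this change. The two measured compounds show that the inhibition in this assay is high for this shared core, but say nothing about how the number will move with the aryl swap. Compound 3 is therefore expected, with wide uncertainty, to give about 70%, within 45% to 90%. That estimate means an expected step of a number 13 percentage points lower from compound 1 to compound 3 (beyond the scatter), a modest loss that may or may not exceed the scatter.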

Compound 3, a percentage reported as inhibition, at one concentration (the size of the read-out at that concentration, not a potency): 91%
For compound 3 the middle estimate is 21 percentage points below the measured one; measured number above the stated range.
By their numbers in this assay, from the lowest: compounds 2, 1 and 3 (each within the scatter of the next, the first and the last beyond it).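

On the sulfonyl sulfur, 3-cyanophenyl can stand in place of 3,5-difluorophenyl with no change that the numbers can separate: the swap gives a number 8 percentage points higher from compound 1 to compound 3 (within the scatter) in this assay at the one concentration tested. The earlier pair varied only the methoxy chain, whereas this step shows that inhibition in this assay stays high with two different aryl groups on the sulfur, one carrying fluorines and the other a nitrile, so the fluorines of compound 1 are not required for a high number. Nothing at hand explains why these two aryl groups give numbers so close together.

The compounds shown leave open whether plain phenyl with no substituent, a pyridyl ring or a phenyl bearing an amine would keep inhibition high on the sulfonyl sulfur, and whether 3-cyanophenyl would behave the same way with hydrogen in place of methoxy on the chain. A percentage at one concentration is also not a potency, so a full concentration series could still reveal differences among these compounds that this read-out does not show.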